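A few compounds are considered here, and "the series" means these few. Any claim that something is new, unique, unknown or untested is made for them only; others in the source may bear on it.

Compound 1 `Cn1c(-c2ccccc2F)cnc1NC(=O)c1ccc(F)cc1`, compound 2 `Cn1c(-c2ccc(C#N)cc2)cnc1NC(=O)c1ccc(F)cc1` and compound 3 `Cc1cccc(-c2cnc(NC(=O)c3ccc(F)cc3)n2C)c1` share one core and differ only in the phenyl group on it: 2-fluorophenyl, 4-cyanophenyl and 3-methylphenyl. In a toxicity assay on THP-1 cells (Homo sapiens) for inhibition (a lower number here means that less compound is tolerated, a higher number that more compound is tolerated), compound 3 gives > 100000 nM, which is a limit and not a number. Compound 1 gives > 100000 nM, which is also a limit. Compound 2 gives > 50000 nM, again a limit. None of the three therefore has a measured half-maximal cytotoxic concentration.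

Compound 4 `Cn1c(-c2cccc(Cl)c2)cnc1NC(=O)c1ccc(F)cc1` has not yet been measured. It departs from compound 3 by chloro in place of methyl on an aromatic carbon, meta to a large group, so that 3-methylphenyl becomes 3-chlorophenyl.

The steps bearing on this change are the other swaps of the phenyl group: a step that the two limits leave unreadable from compound 1 to compound 3, a step that the two limits leave unreadable from compound 2 to compound 3 and a step that the two limits leave unreadable from compound 1 to compound 2. None of them has a readable size, so they offer no measured effect of such a swap, only the fact that all three compounds ended at a limit. The expected change, a number no higher from compound 3 to compound 4 (the limit leaves the size open), is estimated to lie within the scatter, with no direction favoured. Compound 4 is expected at 100000 nM, with an estimated range from 50000 nM to 200000 nM, and it will most likely be reported only as a limit.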

Compound 4, half-maximal cytotoxic concentration: > 50000 nM
Compound 4 was reported as a limit (the forecaster's own chance of this, stated with the estimate: 85%); the middle value does not contradict the limit.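

In this assay compound 4 gives > 50000 nM, which is a limit and not a number. Compound 1, compound 2 and compound 3 also stand at limits, so none of the steps to compound 4 can be read. The compounds shown leave open whether swapping the phenyl group on the shared core changes the half-maximal cytotoxic concentration at all.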